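Triazole-linked diaryl urea series: amine tail variation

The source may report more compounds than this note shows. Statements on the series, on what has been measured and on what is new or still open speak of the compounds shown alone.

Compound 1 `CN(C)CCn1cnnc1-c1cc(Oc2ccc(NC(=O)Nc3cccc(C(F)(F)F)c3)cc2F)ccn1`: 16400 nM
Compound 2 `CCN(CC)CCn1cnnc1-c1cc(Oc2ccc(NC(=O)Nc3cccc(C(F)(F)F)c3)cc2F)ccn1`: 720 nM
Compound 3 `CN(C)CCCn1cnnc1-c1cc(Oc2ccc(NC(=O)Nc3cccc(C(F)(F)F)c3)cc2F)ccn1`: to be measured

Going by the values given here, in a functional assay on MDA-MB-231 cells (Homo sapiens) for antiproliferative activity, read by MTT assay, with a stated time of 72 h (a lower number here means a stronger inhibitor, a higher number a weaker inhibitor), compound 2 gives 720 nM and holds the lowest of the two numbers so far; compound 1 gives 16400 nM. Among the compounds with values here, the one measured step, a 23-fold lower number from compound 1 to compound 2 (1.36 log units; beyond the scatter), concerns the same chain carbon that is changed here. Compound 3 differs from compound 2 by (dimethylamino)methyl in place of diethylamino on a saturated chain carbon, two bonds along the chain from an aromatic nitrogen. This change brings back the dimethylamino of compound 1 while lengthening the chain, so the step bears on it only in part: the tail is again dimethylamino, yet the spacing to the aromatic nitrogen is not that of compound 1. Within the data shown here, the expected step is therefore an increase, a 4.9-fold higher number from compound 2 to compound 3 (0.69 log units; beyond the scatter), weaker than the measured step between compound 1 and compound 2 because of a 23-fold lower number from compound 1 to compound 2 (1.36 log units; beyond the scatter) being the sole guide. Compound 3 is expected to give 3500 nM, within 800 nM to 15000 nM.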

Compound 3, half-maximal inhibitory concentration: 13300 nM
Compound 3: the middle estimate sits 3.8-fold (0.58 log units) below what was measured; the range from low to high includes it.
By their numbers in this assay, from the lowest: compound 2; then compounds 3 and 1 (each within the scatter of the next).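

In this assay, the change is an 18-fold higher number from compound 2 to compound 3 (1.27 log units; beyond the scatter), so 3-(dimethylamino)propyl does not hold the level seen with 2-(diethylamino)ethyl. The comparison with the shorter dimethylamino chain gives a 1.2-fold lower number from compound 1 to compound 3 (0.09 log units; within the scatter), so with a dimethylamino tail, lengthening the chain shows no change beyond the scatter, and among these three compounds only the diethylamino tail of compound 2 stands apart. No measurement is available that accounts for this difference.

The compounds shown leave open whether diethylamino keeps its lower number on the longer chain, as 3-(diethylamino)propyl would show. They also leave open how ring amines such as piperidine or morpholine would compare with diethylamino on the chain of compound 2.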